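Acetyl in place of fluoro on the pendant phenyl ring

The compounds below may be only part of what the source reports. "The series", "measured", "known", "first", "only" and "open" are said of these compounds alone.

Compound 1 `O=Cc1ccc(-c2cn3ccnc3c(-c3ccc4ncn(C5CCCCC5)c4c3)n2)cc1`: 44%
Compound 2 `Fc1ccc(-c2cn3ccnc3c(-c3ccc4ncn(C5CCCCC5)c4c3)n2)cc1`: 9.54%

Compound 2 stands lowest of the two measured numbers in a functional assay on OVCAR-8 cells (Homo sapiens) for inhibition, read by sulforhodamine B assay, with a stated time of 48 h, tested at 10 uM; a higher number here means more inhibition at the concentration tested (going by the name of the read-out), a lower number less inhibition; its nearest neighbour, compound 1, lies a number 34.5 percentage points lower from compound 1 to compound 2 (beyond the scatter). Compound 3 `CC(=O)c1ccc(-c2cn3ccnc3c(-c3ccc4ncn(C5CCCCC5)c4c3)n2)cc1` differs from compound 2 by acetyl in place of fluoro on an aromatic carbon. Among the compounds with values here, the only measured step that bears on this is a number 34.5 percentage points lower from compound 1 to compound 2 (beyond the scatter), and acetyl resembles formyl more closely than fluoro does. The change is therefore expected to run in the opposite direction, as a number 25.5 percentage points higher from compound 2 to compound 3 (beyond the scatter). Compound 3 is estimated at 35%, within 15% to 55%.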

Compound 3, a percentage reported as inhibition, at one concentration (the size of the read-out at that concentration, not a potency): 6.38%
For compound 3 the middle estimate is 28.6 percentage points above the measured one; the measured number lies below the stated range.
By their numbers in this assay, from the lowest: compounds 3 and 2 (each within the scatter of the next); then compound 1.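

In this assay, acetyl in place of fluoro at this position gives a number 3.2 percentage points lower from compound 2 to compound 3 (within the scatter), so a carbonyl on the ring does not by itself match the inhibition of compound 1. Adding one methyl to the formyl carbonyl carbon gives a number 37.6 percentage points lower from compound 1 to compound 3 (beyond the scatter), which shows that this position can tell two closely related groups apart. Nothing measured here explains that gap. On these data alone, it remains open whether formyl stands alone at this position, or whether an amine, a carboxylic acid or a hydroxymethyl group would reach the level of compound 1.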